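Permeability of a cyanobenzazepine sulfonamide series across Caco-2 cells

A few compounds are considered here, and "the series" means these few. Any claim that something is new, unique, unknown or untested is made for them only; others in the source may bear on it.

Measured compounds:
compound 1 `Cn1cncc1CN1CC(N(CC2CCN(C(=O)CNC(=O)OC(C)(C)C)CC2)S(=O)(=O)c2ccccn2)Cc2cc(C#N)ccc21`: 0.5 10^-6 cm/s
compound 2 `Cn1cncc1CN1CC(N(CC2CCN(S(C)(=O)=O)CC2)S(=O)(=O)c2ccccn2)Cc2cc(C#N)ccc21`: 0.1 10^-6 cm/s
compound 3 `Cn1cncc1CN1CC(N(CC2CCN(C(=O)c3ccco3)CC2)S(=O)(=O)c2ccccn2)Cc2cc(C#N)ccc21`: 0.5 10^-6 cm/s

Of the compounds shown here, three share one core and have been tested in an ADME assay on Caco-2 cells (Homo sapiens) for permeability, in the apical to basolateral direction; a lower number here means that the compound crosses the layer more slowly, a higher number that the compound crosses the layer faster. In this assay compound 1 gives 0.5 10^-6 cm/s and compound 3 gives 0.5 10^-6 cm/s; these two lie within the scatter of each other, as no change at the digits printed from compound 1 to compound 3 (within the scatter) shows. Compound 2 gives 0.1 10^-6 cm/s in this assay and stands lowest of the three: a 5.0-fold lower number from compound 1 to compound 2 (0.70 log units; beyond the scatter), and a 5.0-fold higher number from compound 2 to compound 3 (0.70 log units; beyond the scatter).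

Compound 4 `Cn1cncc1CN1CC(N(Cc2ccc(S(C)(=O)=O)cc2)S(=O)(=O)c2ccccn2)Cc2cc(C#N)ccc21` has not yet been measured in this assay. It differs from compound 2 in one place: 4-(methylsulfonyl)phenyl in place of 1-(methylsulfonyl)piperidin-4-yl on a saturated chain carbon bound to a sulfonamide nitrogen

The measured steps all concern what is attached to the ring nitrogen of the piperidine, whereas the change to compound 4 exchanges that ring itself while keeping the methylsulfonyl. Among the compounds with values here, no measured step therefore bears directly on it. Compound 2 already sits at the bottom of the range, and a small rise toward the other two is the most that the data suggest. For compound 4 a step of a 2.0-fold higher number from compound 2 to compound 4 (0.30 log units; within the scatter) is expected, within or barely beyond the scatter. Compound 4 is estimated at 0.2 10^-6 cm/s, with a range from 0.08 10^-6 cm/s to 0.6 10^-6 cm/s.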

Compound 4, apparent permeability: 0.2 10^-6 cm/s
Beside the measured number, compound 4's estimate shows no gap at the digits printed; the measured number falls inside the stated range.
By their numbers in this assay, from the lowest: compounds 2 and 4 (each within the scatter of the next); then compounds 1 and 3 (each within the scatter of the next).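

Within the data shown here, the earlier steps all changed what sits on the ring nitrogen of the piperidine, and this is the first step to exchange the ring itself at this place, on a saturated chain carbon bound to a sulfonamide nitrogen. In this assay, putting 4-(methylsulfonyl)phenyl in place of 1-(methylsulfonyl)piperidin-4-yl gives a 2.0-fold higher number from compound 2 to compound 4 (0.30 log units; within the scatter), so this pair, which keeps the methylsulfonyl, the heavy-atom count and the hydrogen-bond counts while a non-aromatic ring gives way to an aromatic ring of carbon only, shows no separation that can be read beyond the scatter. No evidence accompanies this result that would tie the numbers to any property of either group.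

The compounds shown leave open how the number would respond if the methylsulfonyl on the phenyl ring gave way to a carboxylic acid or an amine, since only this one pair tests the aromatic ring. They also leave open whether a longer chain between the sulfonamide nitrogen and the ring would keep the number within the scatter of that of compound 4, and whether the furan-2-yl carbonyl of compound 3 has any counterpart on the phenyl side.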